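A few compounds are considered here, and "the series" means these few. Any claim that something is new, unique, unknown or untested is made for them only; others in the source may bear on it.

Measured compounds:
- compound 1 `COc1ccc(S(=O)(=O)NCCN2CCC(CCC(=O)c3cc(Cl)c(N)cc3OC)CC2)cc1Cl` gives 20%
- compound 2 `COc1ccc(S(=O)(=O)N2CCC(CCC(=O)c3cc(Cl)c(N)cc3OC)CC2)cc1` is recorded as "not active" (no number reported)

The account concerns an assay on HEK293 cells for displacement of a labelled ligand from 5-hydroxytryptamine receptor 6 (Homo sapiens), with a stated time of 60 min, tested at 0.01 uM, in the presence of a further agent that is not named here; on this read-out lower numbers stand for a weaker effect and higher numbers for a stronger effect at the one concentration tested. In this assay, among the measured compounds shown here, compound 1 gives 20%, the only number available in the set. Compound 2 was reported as "not active" (no number reported), with no number attached, so compound 1 stands alone as the sole quantified point and no ordering among the measured compounds can be drawn from it.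

Compound 3 `COc1ccc(S(=O)(=O)NCCN2CCC(CCC(=O)c3cc(Cl)c(N)cc3OC)CC2)cc1Br` has not yet been measured. It differs from compound 1 by a single change, (bromo in place of chloro on an aromatic carbon), a bromo in place of chloro on an aromatic carbon. For the measured compounds named here, no pair of measured compounds differing in one place exists to calibrate such a change, so the expectation rests on the single value of compound 1. The step of a number 2 percentage points higher from compound 1 to compound 3 (within the scatter) is expected to be small, no larger than the usual scatter, in no particular direction. Compound 3 is therefore estimated to give 22%, in the range 5% to 45%.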

Compound 3, a percentage reported as inhibition, at one concentration (the size of the read-out at that concentration, not a potency): "not active" (no number reported)
No number was reported for compound 3, so the estimate cannot be set against anything.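

Among the compounds shown here, with compound 3 recorded as "not active" (no number reported) in this assay no step from compound 1 to compound 3 can be read. The compounds shown leave open whether bromo in place of chloro changes the read-out at all. No further evidence bears on this result.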